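The compounds below may be only part of what the source reports. "The series", "measured", "known", "first", "only" and "open" are said of these compounds alone.

Measured so far:
- compound 1 `CC(C)[C@@H](N)C(=O)NCc1ccc(COc2cccc(F)c2)cc1`: < 30 mg/kg
- compound 2 `COC[C@@H](N)C(=O)NCc1ccc(OCc2cccc(F)c2)cc1`: 13 mg/kg

In a functional assay on the whole organism (strain albino Sprague-Dawley) with Rattus norvegicus as the target, in the maximal electroshock model (on this read-out higher numbers stand for an effect only at larger amounts of compound and lower numbers for an effect already at smaller amounts), compound 1 gives < 30 mg/kg, which is a limit of the assay rather than a number. In this assay, for the measured compounds named here, compound 2 gives 13 mg/kg, the only plain number so far. Compound 3 `CC(C)(C)[C@@H](N)C(=O)NCc1ccc(OCc2cccc(F)c2)cc1` has not been measured yet; it differs from compound 2 in one place: tert-butyl in place of methoxymethyl on a saturated chain carbon bound to an amine nitrogen and a carbonyl carbon. Going by the values given here, no step between measured compounds is available to weigh this change, so the expectation rests on the structures alone. The step of a 2.3-fold higher number from compound 2 to compound 3 (0.36 log units; beyond the scatter) is expected to run toward larger doses, beyond the usual scatter. Compound 3 is estimated at 30 mg/kg, with a range from 10 mg/kg to 100 mg/kg.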

Compound 3, dose for half-maximal effect: > 30 mg/kg
Compound 3 gave a limit, no number; the forecaster's own chance of this, stated with the estimate: 40%; the middle value lies on the limit itself.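

For the compounds shown here, at this saturated chain carbon bound to an amine nitrogen and a carbonyl carbon, tert-butyl in place of methoxymethyl gives an at least 2.3-fold higher number from compound 2 to compound 3 (0.36 log units; beyond the scatter) in this assay, the first readable step here. So this place is not indifferent to its group: the swap moves the effect toward larger doses. The result for compound 3 is a limit and not a number: the limit of > 30 mg/kg in this assay, at which 1 of the 3 values shown sits.

From the compounds shown here alone, the size of the step beyond this limit stays open, as does what drives it. Going by these compounds, whether a methyl, an ethyl or a longer methoxyethyl chain at this place would behave like methoxymethyl is also open.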